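A few compounds are considered here, and "the series" means these few. Any claim that something is new, unique, unknown or untested is made for them only; others in the source may bear on it.

Working notes on the hydroxamate series in an assay on Sf9 cells for inhibition of protein deacetylase HDAC6 (Homo sapiens), read by fluorescence, with a stated time of 40 min, tested at 100 nM; a higher number here means more inhibition at the concentration tested (going by the name of the read-out), a lower number less inhibition.

Within the data shown here, compound 3 `O=C(NO)c1ccc(NCc2nc(-c3ccc(F)cc3)nn2-c2ccccc2)cc1` gives 70.9% and stands highest of the three numbers measured so far. Its nearest neighbour is compound 1 `Cc1cccc(-c2nc(CNc3ccc(C(=O)NO)cc3)n(-c3ccccc3)n2)c1`, which gives 64.1%; the step of a number 6.8 percentage points higher from compound 1 to compound 3 (within the scatter) lies within the scatter, so the two are not separated. Furthest is compound 2 `O=C(NO)c1ccc(NCc2nc(-c3ccco3)nn2-c2ccccc2)cc1`, which gives 59.9%; the step of a number 11 percentage points higher from compound 2 to compound 3 (beyond the scatter) lies beyond the scatter, a modest gain.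

Compound 4 `O=C(NO)c1ccc(NCc2nc(-c3ccccc3Cl)nn2-c2ccccc2)cc1` is next in line. Its change from compound 3 is 2-chlorophenyl in place of 4-fluorophenyl on an aromatic carbon. The two measured steps that exchange a group at this same carbon are a number 6.8 percentage points higher from compound 1 to compound 3 (within the scatter) and a number 11 percentage points higher from compound 2 to compound 3 (beyond the scatter); one is within the scatter, the other just beyond it, so exchanges of the aryl group at this carbon have moved the inhibition only a little in either direction. A 2-chlorophenyl has not been tried, so there is no direct guide for its direction. Compound 4 is therefore expected to sit close to compound 3, with any step a number 5.9 percentage points lower from compound 3 to compound 4 (within the scatter) expected to stay within the scatter. Compound 4 is estimated at 65%, with a range from 50% to 78%.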

Compound 4, a percentage reported as inhibition, at one concentration (the size of the read-out at that concentration, not a potency): 75%
Estimate against measurement, compound 4: 10 percentage points below; measured number inside the range.
By their numbers in this assay, from the lowest: compounds 2, 1, 3 and 4 (each within the scatter of the next, the first and the last beyond it).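

In this assay the 2-chlorophenyl group is accepted at this carbon, and the step of a number 4.1 percentage points higher from compound 3 to compound 4 (within the scatter) leaves compound 4 unseparated from compound 3, so these two aryl groups cannot be ordered. The new information lies in the wider comparison: the step of a number 10.9 percentage points higher from compound 1 to compound 4 (beyond the scatter) is beyond the scatter, whereas the step of a number 6.8 percentage points higher from compound 1 to compound 3 (within the scatter) is not, and the step of a number 15.1 percentage points higher from compound 2 to compound 4 (beyond the scatter) is also beyond it, at a modest size, so 2-chlorophenyl is separated from both 3-methylphenyl and furan-2-yl, while 4-fluorophenyl is separated only from furan-2-yl. No measurement on these compounds accounts for these differences between the groups.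

The change from compound 3 to compound 4 alters both the halogen and its place on the phenyl ring, so the contribution of each remains unresolved. All four compounds carry an aromatic ring at this carbon, which leaves open how a non-aromatic group such as a morpholine or a short alkyl chain, or a phenyl ring bearing a carboxylic acid or an amine, would read in this series.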